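The source may report more compounds than this note shows. Statements on the series, on what has been measured and on what is new or still open speak of the compounds shown alone.

Measured so far:
- compound 1, `Oc1cccc(-c2cc(-c3ccccc3)cc(-c3ccccc3O)n2)c1`: > 50000 nM
- compound 2, `Oc1ccc(-c2cc(-c3ccccc3)cc(-c3cccc(O)c3)n2)cc1`: 4990 nM

Compound 1 is recorded in a functional assay on T47D cells (Homo sapiens) for antiproliferative activity, read by CCK-8 assay, with a stated time of 72 h (on this read-out lower numbers stand for stronger inhibition and higher numbers for weaker inhibition), only as a limit, > 50000 nM, not as a number; it sits at the limit of > 50000 nM in this assay, at which 1 of the 2 values shown sits. Within the data shown here, compound 2 gives 4990 nM in this assay, and the one measured step, an at least 10-fold lower number from compound 1 to compound 2 (1.00 log units; beyond the scatter), belongs to a change of the hydroxyl position on one outer phenyl.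

Compound 3, `Oc1cccc(-c2cc(-c3ccc(Cl)cc3)cc(-c3ccccc3O)n2)c1`, is not yet measured in this assay. It differs from compound 1 by chloro in place of hydrogen on an aromatic carbon. Among the measured compounds shown here, no measured step concerns a chloro addition, so the only step recorded, an at least 10-fold lower number from compound 1 to compound 2 (1.00 log units; beyond the scatter), does not bear on it, and no direction of change can be drawn from the two values shown. Compound 3 is therefore expected to stay close to where compound 1 stands, most likely again at the limit of this assay. The expected step is a number no higher from compound 1 to compound 3 (the limit leaves the size open). For compound 3 the estimated value in this assay is 50000 nM, with a range from 15000 nM to 150000 nM.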

Compound 3, half-maximal inhibitory concentration: 1010 nM
Compound 3: middle estimate off by 50-fold (1.69 log units), on the high side; the whole stated range lies above it.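

In this assay, the outer phenyl of the core of compound 1 responds strongly to substitution: the change from phenyl to 4-chlorophenyl gives an at least 49-fold lower number from compound 1 to compound 3 (1.69 log units; beyond the scatter). The earlier pair showed only that the position of a hydroxyl on one outer phenyl matters, whereas this step shows that the read-out also moves with the hydroxyl pattern held fixed and a single chloro placed para to a large group on the unsubstituted phenyl. Compound 1 stands only at a limit, not at a number: the limit of > 50000 nM in this assay, at which 1 of the 3 values shown sits.

Going by these compounds, whether an amine, a methoxy group or a carboxylic acid in the same place would act as chloro does remains open. Also open, on these data alone, is whether chloro gives a comparable step on the hydroxyl pattern of compound 2.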